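Dropping the 3-methoxyphenyl group from compound 2

The source may report more compounds than this note shows. Statements on the series, on what has been measured and on what is new or still open speak of the compounds shown alone.

Compound 1 `COc1cccc(N2C(=O)COc3ccc(-c4cnc(Cl)c(NS(=O)(=O)c5ccc(F)cc5)c4)cc32)c1`: > 40000 nM (a limit of the assay)
Compound 2 `COc1cccc(N2C(=O)COc3ccc(-c4cnc5ccccc5c4)cc32)c1`: 23600 nM

In a functional assay on A-375 cells (Homo sapiens) for antiproliferative activity, read by MTT assay, with a stated time of 72 h (a lower number here means a stronger inhibitor, a higher number a weaker inhibitor), compound 1 gives only a limit, > 40000 nM. Within the data shown here, compound 2 gives 23600 nM, the only actual number so far. Compound 3 `O=C1COc2ccc(-c3cnc4ccccc4c3)cc2N1` differs from compound 2 in one place: hydrogen in place of 3-methoxyphenyl on an amide-type nitrogen in a ring. Among the measured compounds shown here, no measured pair shows what this change does, so no step beyond the scatter is expected, with a slight lean toward weaker inhibition. The expected change is a 1.2-fold higher number from compound 2 to compound 3 (0.07 log units; within the scatter). For compound 3 the estimate is 28000 nM, with an expected range of 12000 nM to 40000 nM.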

Compound 3, half-maximal inhibitory concentration: > 40000 nM
Compound 3 gave a limit, no number (the forecaster's own chance of this, stated with the estimate: 40%); middle value at least 1.4-fold (0.15 log units) away from the limit.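

Among these compounds, this is the first look at the amide-type nitrogen in the ring: in this assay, hydrogen in place of 3-methoxyphenyl gives an at least 1.6-fold higher number from compound 2 to compound 3 (0.22 log units; that floor lies within the scatter). That floor lies within the scatter, so the data do not show that the 3-methoxyphenyl group is needed for the activity of compound 2. The true size of the step stays hidden, since it is bounded only by the top of the assay's range: the limit of > 40000 nM in this assay, at which 2 of the 3 values shown sit.

Going by these compounds, what a methyl or a benzyl group on this nitrogen would do stays open, as does whether any group here could bring the number well below that of compound 2.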